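Aryl variation on the shared core: compound 3 to compound 4

A few compounds are considered here, and "the series" means these few. Any claim that something is new, unique, unknown or untested is made for them only; others in the source may bear on it.

Measured so far in an assay on isolated protein for inhibition of protein deacetylase HDAC6 (Homo sapiens); a lower number here means a stronger inhibitor, a higher number a weaker inhibitor:
compound 1 `Cc1ccc(-c2noc(-c3ccc(C(=O)C(F)(F)F)s3)n2)cc1`, 860 nM
compound 2 `O=C(c1ccc(-c2nnc(-c3ccccc3)o2)s1)C(F)(F)F`, 330 nM
compound 3 `O=C(c1ccc(-c2nc(-c3cccnc3)no2)s1)C(F)(F)F`, 840 nM

Compound 3 gives the second highest of the three numbers in this assay. Among the compounds with values here, compound 1 is nearest to it and within the scatter; compound 2 gives the lowest number of the set, and the gap from compound 3 to compound 2 is beyond the scatter, though no single-place step between these two is counted here.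

Compound 4 `O=C(c1ccc(-c2nc(-c3ccc(Cl)cc3Cl)no2)s1)C(F)(F)F` is not yet measured. It differs from compound 3 as follows: 2,4-dichlorophenyl in place of pyridin-3-yl on an aromatic carbon.

Within the data shown here, one measured step bears on this position, a 1.0-fold lower number from compound 1 to compound 3 (0.01 log units; within the scatter), which is within the scatter. Swapping one six-membered aromatic ring for another at this aromatic carbon has so far not moved the number beyond the scatter, so for compound 4 no step beyond the scatter is expected; the expected step is a 1.2-fold lower number from compound 3 to compound 4 (0.08 log units; within the scatter). Compound 4 is therefore estimated at 700 nM in this assay, with a range from 250 nM to 2000 nM.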

Compound 4, half-maximal inhibitory concentration: 3000 nM
Estimate against measurement, compound 4: 4.3-fold (0.63 log units) below; the whole stated range lies below it.
By their numbers in this assay, from the lowest: compound 2; then compounds 3 and 1 (each within the scatter of the next); then compound 4.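

In this assay the choice of aryl group on this aromatic carbon does matter: 2,4-dichlorophenyl in place of pyridin-3-yl gives a 3.6-fold higher number from compound 3 to compound 4 (0.55 log units; beyond the scatter), and in place of 4-methylphenyl it gives a 3.5-fold higher number from compound 1 to compound 4 (0.54 log units; beyond the scatter). Pyridin-3-yl and 4-methylphenyl stay level within the scatter, so among the three groups shown at this position, only 2,4-dichlorophenyl separates from the others, and the step is of similar size whichever of the two it replaces. No measurement on these compounds accounts for this step.

The compounds shown do not tell whether the two chlorine atoms act together or one alone carries the step. Going by these compounds, whether a phenyl ring with a single chlorine, or a saturated amine such as piperidine on this carbon, would stay level with compound 3 or move towards compound 4 remains open.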